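The source may report more compounds than this note shows. Statements on the series, on what has been measured and on what is new or still open speak of the compounds shown alone.

Two compounds of the series have been run in a functional assay on MCF7 cells (Homo sapiens) for inhibition, read by MTT assay, with a stated time of 72 h; a lower number here means a stronger inhibitor, a higher number a weaker inhibitor. Compound 1 `CN(C(=O)NC(=O)c1ccc(F)c(F)c1)c1nc(C(F)(F)F)c(C(=O)N/N=C/c2ccc(C(F)(F)F)cc2)s1` gives 5.93 ug/mL. Compound 2 `CN(C(=O)NC(=O)c1ccc(F)c(F)c1)c1nc(C(F)(F)F)c(C(=O)N/N=C/c2ccccc2C(F)(F)F)s1` gives 8.21 ug/mL, the higher of the two numbers shown, though the step of a 1.4-fold higher number from compound 1 to compound 2 (0.14 log units; within the scatter) lies within the scatter, so the two compounds cannot be separated. Compound 3 `CN(C(=O)NC(=O)c1ccccc1F)c1nc(C(F)(F)F)c(C(=O)N/N=C/c2ccccc2C(F)(F)F)s1` has not been measured. It differs from compound 2 in one place: 2-fluorophenyl in place of 3,4-difluorophenyl on a carbonyl carbon. Among the measured compounds shown here, the single measured step alters the ring on the carbon with a double bond to nitrogen and leaves the carbonyl-bound ring untouched, so no measured step bears on the present change, and nothing in the data supports a shift in either direction. Compound 3 is therefore expected to sit close to compound 2, with an expected step of a 1.0-fold lower number from compound 2 to compound 3 (0.01 log units; within the scatter), none beyond the scatter. The estimate for compound 3 is 8 ug/mL, within a range from 4 ug/mL to 16 ug/mL.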

Compound 3, half-maximal inhibitory concentration: 12.2 ug/mL
Compound 3: the middle estimate sits 1.5-fold (0.18 log units) below what was measured; the range from low to high includes it.
By their numbers in this assay, from the lowest: compounds 1, 2 and 3 (each within the scatter of the next, the first and the last beyond it).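

The carbonyl-bound ring now has a measured step of its own: in this assay, 2-fluorophenyl in place of 3,4-difluorophenyl on a carbonyl carbon gives a 1.5-fold higher number from compound 2 to compound 3 (0.17 log units; within the scatter), so compound 2 and compound 3 cannot be separated. Losing one fluorine and changing the fluorine pattern on this ring therefore produces no readable change, just as the earlier exchange of trifluoromethylphenyl isomers on the other ring produced none. No supporting data are available to explain this result.

From the compounds shown here alone, whether this position responds to anything other than a fluorophenyl ring remains open, for example an unsubstituted phenyl, a methoxyphenyl, a morpholine or a short alkyl chain on the carbonyl carbon. Also open, going by these compounds, is whether a carboxylic acid on this ring would give a step beyond the scatter.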